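Compound 3: a larger aromatic group replaces methoxy

The source may hold more compounds than are shown below. What is called first, only, known or untested is meant among the compounds shown, and "the series" means these compounds.

In a toxicity assay on NIH3T3 cells (Mus musculus) for cytotoxicity, read by resazurin assay (on this read-out higher numbers stand for an effect only at larger amounts of compound and lower numbers for an effect already at smaller amounts), compound 1 (`Clc1ccc(NCc2cncn2Cc2ccc(-c3ccccc3)cc2)cc1-c1ccccc1`) gives > 1000 nM as a limit of the assay and not a number. Compound 2 (`COc1ccc(NCc2cncn2Cc2ccc(-c3ccccc3)cc2)cc1-c1ccccc1`) gives > 1000 nM as a limit as well, so it stands without a number of its own. Compound 3 (`c1ccc(-c2ccc(Cn3cncc3CNc3ccc(-c4onc5ccccc45)c(-c4ccccc4)c3)cc2)cc1`) differs from it by a group of 9 heavy atoms (7 carbon, 1 nitrogen, 1 oxygen; one five-membered aromatic ring with 2 hetero atoms, one six-membered aromatic ring of carbon only) in place of a group of 2 heavy atoms (1 carbon, 1 oxygen; no ring), on an aromatic carbon on an aromatic carbon, ortho to a phenyl group. Within the data shown here, only one measured step bears on this carbon: a step that the two limits leave unreadable from compound 1 to compound 2 for methoxy in place of chloro. Both values sit at the limit of > 1000 nM in this assay, at which 2 of the 2 values shown sit, in the data so far, which gives no size to carry over and no direction. Compound 3 is therefore expected to stay near that limit in this assay and most likely to be reported as a limit again. The expected change is a step that the limit leaves unreadable from compound 2 to compound 3 and no shift beyond the scatter can be argued. For compound 3 the estimate is 2500 nM, with an expected range of 800 nM to 10000 nM in this assay as well.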

Compound 3, half-maximal effective concentration: > 10000 nM
Compound 3: no number, only a limit; the forecaster's own chance of this, stated with the estimate: 75%; at least 4.0-fold (0.60 log units) between middle value and limit.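

In this assay, among these compounds, compound 1, compound 2 and compound 3 are all reported as limits of the assay and not as numbers, and no step among them can be read. The compounds shown leave open whether any replacement on this aromatic carbon changes the cytotoxic effect at all, and by how much.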